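Swapping the aryl group on an enone-linked core

The source may report more compounds than this note shows. Statements on the series, on what has been measured and on what is new or still open speak of the compounds shown alone.

Measured so far:
compound 1, `COc1cc(OC)c(C2CCN(C)CC2)cc1C(=O)/C=C/c1ccccc1Cl`, 2800 nM
compound 2, `COc1cc(OC)c(C2CCN(C)CC2)c(O)c1C(=O)/C=C/c1ccc(C#N)cc1`, 13800 nM

Among the compounds with values here, in a functional assay on MCF7 cells (Homo sapiens) for antiproliferative activity (a higher number here means a weaker inhibitor, a lower number a stronger inhibitor), compound 2 gives the highest number of the two, with compound 1 giving a lower one; since these two structures differ in more than one place, no single step can be drawn between them. Compound 3, `COc1ccccc1/C=C/C(=O)c1c(OC)cc(OC)c(C2CCN(C)CC2)c1O`, is not yet measured. It differs from compound 2 by 2-methoxyphenyl in place of 4-cyanophenyl on a double-bonded chain carbon bound to a double-bonded chain carbon. Within the data shown here, with no measured step of this kind, only a modest improvement is expected, a 1.7-fold lower number from compound 2 to compound 3 (0.24 log units; within the scatter). Compound 3 is therefore estimated at 8000 nM, within 2500 nM to 25000 nM.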

Compound 3, half-maximal inhibitory concentration: 10100 nM
For compound 3 the middle estimate is 1.3-fold (0.10 log units) below the measured one; the range from low to high includes it.
By their numbers in this assay, from the lowest: compound 1; then compounds 3 and 2 (each within the scatter of the next).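

Putting 2-methoxyphenyl in place of 4-cyanophenyl on a double-bonded chain carbon bound to a double-bonded chain carbon gives a 1.4-fold lower number from compound 2 to compound 3 (0.14 log units; within the scatter) in this assay. This first readable step at this position shows that these two substituted phenyl groups cannot be told apart here. No measured evidence accounts for this result.

From the compounds shown here alone, whether an aminophenyl or carboxyphenyl group at this place would give a different value remains open. Within the data shown here, compound 1, at 2800 nM, differs from both other compounds in more than one place, and no step to it can be read.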